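The source may hold more compounds than are shown below. What is called first, only, known or untested is meant among the compounds shown, and "the series" means these compounds.

Measured compounds:
- compound 1, `O=C(O)CC1COc2cc(OCc3cccc(N4CCCC4)c3)ccc21`, gives 43.7% in a functional assay on CHO cells for agonist activity at Free fatty acid receptor 1 (Homo sapiens), read by FLIPR and calcium flux, with a stated time of 90 s, tested at 100 nM; a lower number here means a weaker effect, a higher number a stronger effect of the compound at the concentration tested
- compound 2, `Cc1ccc(C)n1-c1cccc(COc2ccc3c(c2)OCC3CC(=O)O)c1`, gives 59.9% in this assay

Among the measured compounds shown here, compound 2 stands higher of the two measured values in this assay; the only other compound, compound 1, lies lower by a number 16.2 percentage points higher from compound 1 to compound 2 (beyond the scatter), a step beyond the scatter. Compound 3, `COCc1cc(C)n(-c2cccc(COc3ccc4c(c3)OCC4CC(=O)O)c2)c1C`, has not yet been measured. It differs from compound 2 by methoxymethyl in place of hydrogen on an aromatic carbon.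

For the measured compounds named here, the single measured step exchanged one whole ring group for another, pyrrolidin-1-yl for 2,5-dimethyl-1H-pyrrol-1-yl, and it was of modest size. Going by the values given here, no measured step adds a group onto the 2,5-dimethyl-1H-pyrrol-1-yl ring itself, so nothing measured speaks directly to this change. Among the compounds with values here, with only that indirect guide, compound 3 is expected to stay close to compound 2, a step of a number 0.1 percentage points higher from compound 2 to compound 3 (within the scatter), not clearly beyond the scatter. The estimate for compound 3 in this assay is therefore 60%, within the range 35% to 85%.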

Compound 3, a percentage reported as activity, at one concentration (the size of the read-out at that concentration, not a potency): 31.7%
For compound 3 the middle estimate is 28.3 percentage points above the measured one; measured number below the stated range.
By their numbers in this assay, from the lowest: compound 3; then compound 1; then compound 2.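

Adding to the 2,5-dimethyl-1H-pyrrol-1-yl ring is not a neutral change in this assay: methoxymethyl in place of hydrogen, on the aromatic carbon next to the ring atom that bears a methyl group, gives a number 28.2 percentage points lower from compound 2 to compound 3 (beyond the scatter) and so cancels the earlier advantage of this ring. The decrease is large enough that a number 12 percentage points lower from compound 1 to compound 3 (beyond the scatter) is also seen, so the substituted ring now falls short of the pyrrolidin-1-yl group it replaces. No measurement offered here explains this loss, and its cause remains unknown.

The compounds shown cannot separate an effect of methoxymethyl itself from an effect of placing any group on this carbon. A smaller group such as hydroxymethyl, or a carbon-only chain such as ethyl, at the same place would begin to draw that distinction.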